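The source may report more compounds than this note shows. Statements on the series, on what has been measured and on what is new or still open speak of the compounds shown alone.

Within the data shown here, in a functional assay (aorta) with Rattus norvegicus as the target (a higher number here means that more compound is needed for the effect, a lower number that less compound is needed), two compounds carry a number so far. Compound 1 (`C/N=C(/S)C1=CC(CF)(CF)Oc2ccc([N+](=O)[O-])cc21`) gives 0.479 nM and compound 2 (`CNC(=O)C1=CC(C)(CF)Oc2ccc([N+](=O)[O-])cc21`) gives 8.91 nM in the same read-out. Compound 2 thus holds the higher of the two numbers, and its distance from compound 1 lies beyond the usual scatter. Compound 3 (`CNC(=O)C1=CC(CF)(CF)Oc2ccc([N+](=O)[O-])cc21`) is still to be measured in this assay and differs from compound 2 in one place, by fluoro in place of hydrogen on a saturated chain carbon bound to a saturated ring carbon in the count of what leaves and enters. In words, this is fluoro in place of hydrogen on a saturated chain carbon bound to a saturated ring carbon, which reads as methyl to fluoromethyl when cut one bond further out. Among the measured compounds shown here, no step between measured compounds shows what this change does, so the expectation remains loose. The estimate is a 1.8-fold lower number from compound 2 to compound 3 (0.25 log units; within the scatter) as an expected move, small and toward a lower number, and it may not clear the scatter. Compound 3 is expected at 5 nM (estimated range 1.5 nM to 18 nM) once it has been measured.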

Compound 3, half-maximal effective concentration: 5.13 nM
Beside the measured number, compound 3's estimate is 1.0-fold (0.01 log units) below it; measured number inside the range.
By their numbers in this assay, from the lowest: compound 1; then compounds 3 and 2 (each within the scatter of the next).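

In this assay the change from methyl to fluoromethyl, on a saturated chain carbon bound to a saturated ring carbon, gives a 1.7-fold lower number from compound 2 to compound 3 (0.24 log units; within the scatter) and so does not separate the two compounds at this place in this read-out. The other new step, an 11-fold higher number from compound 1 to compound 3 (1.03 log units; beyond the scatter) on exchanging the group of 4 heavy atoms that holds sulfur for the one that holds oxygen on a double-bonded ring carbon, is large, and of the two single changes now in hand only this one lies beyond the scatter. Nothing at hand gives a reason for either step.

Among these compounds, what remains open is whether the same fluoro change would also stay within the scatter with the sulfur group of compound 1 on the double-bonded ring carbon, since both compounds that hold that comparison's fluoromethyl pair share only this one core. Also open, as far as these compounds go, is how a trifluoromethyl group or a longer chain would read at the saturated chain position, and how a nitrile or a carboxylic acid would read on the double-bonded ring carbon.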